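Shortening One Side Chain on the Top Compound

The source may hold more compounds than are shown below. What is called first, only, known or untested is meant among the compounds shown, and "the series" means these compounds.

In a physicochemical assay for solubility, in phosphate buffer, at pH 7.4 (on this read-out lower numbers stand for lower solubility and higher numbers for higher solubility), compound 1 `CNC(=O)CN1CCC(c2cc3c(-c4ccc(=O)n(C(C)C)c4)ccnc3[nH]2)CC1` gives 34000 nM and compound 2 `COc1cc(F)ccc1-c1ccnc2[nH]c(C3CCN(CC(=O)N(C)C)CC3)cc12` gives 38000 nM. Compound 3 `CC(C)Cn1cc(-c2ccnc3[nH]c(C4CCN(CC(=O)N(C)C)CC4)cc23)ccc1=O` reaches 390000 nM, the highest of the three and beyond the usual scatter from both others. Compound 4 `CCn1cc(-c2ccnc3[nH]c(C4CCN(CC(=O)N(C)C)CC4)cc23)ccc1=O` has not yet been measured. It differs from compound 3 by methyl in place of isopropyl on a saturated chain carbon bound to an aromatic nitrogen; cut one bond further out, this reads isobutyl to ethyl. Going by the values given here, no measured pair shows this change, so the expectation leans only on the top position of compound 3 at 390000 nM. In this assay, a modest fall is expected, a 2.2-fold lower number from compound 3 to compound 4 (0.34 log units; beyond the scatter), near the edge of the scatter. For compound 4 the estimate is 180000 nM, with an expected range of 60000 nM to 450000 nM.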

Compound 4, solubility: > 1000000 nM
Compound 4: only a limit was reported (the forecaster's own chance of this, stated with the estimate: 10%); middle value at least 5.5-fold (0.74 log units) away from the limit.
By their numbers in this assay, from the lowest: compounds 1 and 2 (each within the scatter of the next); then compound 3. At a limit, above all of these: compound 4.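

In this assay, going by these compounds alone, the first direct look at this position shows that the shorter chain does not lower the number: methyl in place of isopropyl gives an at least 2.5-fold higher number from compound 3 to compound 4 (0.40 log units; beyond the scatter). With the ethyl chain in place, a ring with one hetero atom instead of the carbon-only aromatic ring of compound 2 gives an at least 26-fold higher number from compound 2 to compound 4 (1.42 log units; beyond the scatter). The figure for compound 4 is a limit, not a number: the limit of > 1000000 nM in this assay, at which 1 of the 4 values shown sits.

From the compounds shown here alone, the true size of both steps stays open. So does what a longer chain, or a chain carrying an amine or a carboxylic acid, would give at this place.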